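A few compounds are considered here, and "the series" means these few. Any claim that something is new, unique, unknown or untested is made for them only; others in the source may bear on it.

Compound 1 `COc1ccc(CNc2nc(SC)nc3ccccc23)cc1` shows weak inhibition of growth in an ADME assay on BEAS-2B cells (Homo sapiens) for cytotoxicity, read by MTT assay, with a stated time of 72 h (on this read-out lower numbers stand for stronger inhibition of growth and higher numbers for weaker inhibition of growth), where compound 1 gives 21700 nM. Compound 2 `Nc1nc([SeH])nc2ncccc12` is built on a different core, and in this assay compound 2 gives 5890 nM. Compound 3 `C[Se]c1nc([Se]C)c2cccnc2n1` shares that second core but carries two methylseleno groups; in this assay compound 3 gives "not determined" (no result reported), so compound 3 stands without any single number against which a neighbour could be measured. Compound 4 `C[Se]c1nc(N)c2cccnc2n1` is the neighbour in question, and its change from compound 3 is one nitrogen atom in place of a group of 2 heavy atoms (1 carbon, 1 selenium; no ring), on an aromatic carbon. Among the compounds with values here, no step between two measured compounds is recorded here, so the size of the step from compound 3 to compound 4 in this assay cannot be read from any measured pair; what remains is the two measured compounds, whose values differ from each other beyond the usual scatter. Since compound 2 also carries an amino group on the same core and gives 5890 nM, compound 4 is expected to give 8000 nM in this assay, with a range from 2500 nM to 30000 nM covering what such an estimate can claim.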

Compound 4, concentration for 50% growth inhibition: 39700 nM
Compound 4: the middle estimate sits 5.0-fold (0.70 log units) below what was measured; measured number above the stated range.
By their numbers in this assay, from the lowest: compound 2; then compounds 1 and 4 (each within the scatter of the next).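

In this assay, the selenium of the shared core now has a measured one-place change: with the amino group kept, methyl in place of hydrogen on a selenium gives a 6.7-fold higher number from compound 2 to compound 4 (0.83 log units; beyond the scatter), which means weaker inhibition of growth on this read-out. The earlier compounds shown here offered no such pair, and the step from compound 3 to compound 4, the amino group entering on an aromatic carbon opposite the ring nitrogen, cannot be read, since compound 3 has no number; the effect of that amino group at this position therefore remains unmeasured here, and only the change on the selenium has a size. Nothing in the available evidence explains why the methyl on the selenium goes with the higher number.

The compounds shown leave open whether an ethyl group or a longer chain on the selenium would move the number further from that of compound 2 or bring it back, as a single step says nothing about a trend. They also leave open how a methylamino group or a morpholine in place of the amino group would read on this core, and whether a methylthio group in place of the methylseleno group of compound 4 would give a similar number.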